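Swapping Methyl for Chloro on an Aromatic Carbon

This account rests on a few compounds, and the source may have more. Where it says the series, first, only, none or still open, it means among the compounds named here.

In a functional assay on B16 cells (Mus musculus) for inhibition (a higher number here means a weaker inhibitor, a lower number a stronger inhibitor), compound 1 `O=C(CCc1ccc(O)c(O)c1)O[C@@H]1C[C@](O)(C(=O)O)C[C@@H](O)[C@H]1O` gives only a limit, > 40000 nM.

Compound 2 `CC(C)c1ccc(NC(=O)/C=C/c2ccc(O)c(O)c2)cc1` gives a true number, 3400 nM. Compound 3 `Cc1cccc(CNC(=O)/C=C/c2ccc(O)c(O)c2)c1` gives 3000 nM, which lies within the usual scatter of the result for compound 2, so these two inhibitors cannot be told apart in this test.

Compound 4 `O=C(/C=C/c1ccc(O)c(O)c1)NCc1cccc(Cl)c1` has not yet been measured. It differs from compound 3 in a single place: chloro in place of methyl on an aromatic carbon. In words, this is chloro in place of methyl on an aromatic carbon, meta to a large group.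

Among the measured compounds shown here, no measured pair here shows this kind of change, so the data offer no direct guide to its effect. The best anchor is compound 3 at 3000 nM, and the expectation in this assay is a small step towards a lower number, probably not beyond the scatter. The estimated step runs a 1.2-fold lower number from compound 3 to compound 4 (0.08 log units; within the scatter). Compound 4 is expected at about 2500 nM, with an estimated range of 1000 nM to 6000 nM.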

Compound 4, half-maximal inhibitory concentration: 6000 nM
For compound 4 the middle estimate is 2.4-fold (0.38 log units) below the measured one; the measured number falls inside the stated range.
By their numbers in this assay, from the lowest: compounds 3, 2 and 4 (each within the scatter of the next). At a limit, above all of these: compound 1.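

Among the compounds shown here, this is the first pair in the set that differs in one place, so it gives the first direct reading of a change on this ring. In this assay, chloro in place of methyl on the aromatic carbon gives a 2.0-fold higher number from compound 3 to compound 4 (0.30 log units; within the scatter), so the two compounds cannot be told apart in this test. At this position, then, either group gives a true number rather than a limit, and this single pair shows no clear difference between methyl and chloro. No available evidence bears on this step.

A single pair says nothing about how a quite different group in the same place, such as an amine, a carboxylic acid or a methoxy group, would read in this assay. It also leaves open whether chloro would give a similar result elsewhere on the ring.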